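From benzyl to 3-chlorophenyl on the shared core

The compounds below may be only part of what the source reports. "The series", "measured", "known", "first", "only" and "open" are said of these compounds alone.

- compound 1 `Nc1ccccc1NC(=O)c1ccc(Cn2cnc3c(NCc4ccccc4)nc(Cl)nc32)cc1` gives 11200 nM
- compound 2 `CC(C)n1cnc2c(NCc3ccc(C(=O)Nc4ccccc4N)cc3)nc(Cl)nc21` gives 3410 nM

In a functional assay on NCI-H460 cells (Homo sapiens) for antiproliferative activity, read by CCK-8 assay, with a stated time of 72 h (a lower number here means a stronger inhibitor, a higher number a weaker inhibitor), compound 1 (11200 nM) holds the higher of the two numbers, and compound 2 (3410 nM) lies lower by a gap beyond the scatter. Compound 3 `Nc1ccccc1NC(=O)c1ccc(Cn2cnc3c(Nc4cccc(Cl)c4)nc(Cl)nc32)cc1` carries 3-chlorophenyl in place of benzyl on a nitrogen on an aromatic ring. For the measured compounds named here, no measured pair shows this change on its own, so the expectation is tentative. In this assay a small estimated step toward a lower number is expected (a 1.9-fold lower number from compound 1 to compound 3 (0.27 log units; within the scatter)). For compound 3 the estimated value is 6000 nM (range 2000 nM to 18000 nM).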

Compound 3, half-maximal inhibitory concentration: 6580 nM
Compound 3: middle estimate off by 1.1-fold (0.04 log units), on the low side; the range from low to high includes it.
By their numbers in this assay, from the lowest: compounds 2, 3 and 1 (each within the scatter of the next, the first and the last beyond it).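

In this assay, putting 3-chlorophenyl in place of benzyl on a nitrogen on an aromatic ring gives a 1.7-fold lower number from compound 1 to compound 3 (0.23 log units; within the scatter) on the shared core. This position therefore accepts (3-chlorophenyl)amino in place of benzylamino without a difference that can be told from the scatter. Nothing measured here explains why the two groups read alike.

This swap adds the chlorine and removes the carbon link at once, so the compounds shown do not separate the two. As far as these compounds go, how a plain phenyl or a 3-chlorobenzyl on the same nitrogen would read remains open.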